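From 2,3-dichlorophenyl to 4-cyanophenyl on a shared core

The source may hold more compounds than are shown below. What is called first, only, known or untested is meant among the compounds shown, and "the series" means these compounds.

Compound 1 `COC(=O)C1=C(C)N=C(C)/C(=C(\O)OC)C1c1ccc(I)cc1`: 22900 nM
Compound 2 `COC(=O)C1=C(C)N=C(C)/C(=C(\O)OC)C1c1cccc(Cl)c1Cl`: 19.1 nM

In a functional assay (muscle tissue) with Cavia porcellus as the target (a higher number here means that more compound is needed for the effect, a lower number that less compound is needed), compound 2 has the lower of the two numbers, at 19.1 nM. Compound 3 `COC(=O)C1=C(C)N=C(C)/C(=C(\O)OC)C1c1ccc(C#N)cc1` places 4-cyanophenyl where compound 2 carries 2,3-dichlorophenyl on a saturated ring carbon: 4-cyanophenyl in place of 2,3-dichlorophenyl on a saturated ring carbon. Within the data shown here, one measured step bears on this change: a 1200-fold lower number from compound 1 to compound 2 (3.08 log units; beyond the scatter), a large step beyond the scatter, where 2,3-dichlorophenyl replaced 4-iodophenyl. Compound 3 also loses 2,3-dichlorophenyl, so a large step to a higher number is expected in this assay, though compound 3 is expected to possibly keep a lower number than compound 1, which gives 22900 nM. The expected step is a 100-fold higher number from compound 2 to compound 3 (2.02 log units; beyond the scatter). For compound 3 the estimate is 2000 nM, with an expected range from 300 nM to 12000 nM.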

Compound 3, half-maximal effective concentration: 3470 nM
For compound 3 the middle estimate is 1.7-fold (0.24 log units) below the measured one, within the range that was stated.
By their numbers in this assay, from the lowest: compound 2; then compound 3; then compound 1.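

In this assay the move to 4-cyanophenyl gave a 180-fold higher number from compound 2 to compound 3 (2.26 log units; beyond the scatter) and so 2,3-dichlorophenyl keeps the lowest number of the three, with its steps to 4-iodophenyl and 4-cyanophenyl both beyond the scatter. Cyano in place of iodo gave a 6.6-fold lower number from compound 1 to compound 3 (0.82 log units; beyond the scatter) as a modest step, so the choice of group on the 4-substituted phenyl also counts, though less than the change to 2,3-dichlorophenyl. Nothing measured here gives a reason for either step.

The compounds shown leave open whether a single chlorine on the phenyl ring would suffice. From the compounds shown here alone, whether an amine or a carboxylic acid there would be tolerated also remains open.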